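This account rests on a few compounds, and the source may have more. Where it says the series, first, only, none or still open, it means among the compounds named here.

Among the measured compounds shown here, compound 1, with the structure `NC(=O)c1ccc(-c2ccc(F)c(C(=O)Nc3c[nH]nc3C(=O)Nc3ccc(F)cc3)c2F)cn1`, is the only compound here that comes with a number. In a functional assay on A2058 cells (Homo sapiens) for antiproliferative activity, read by luminescence and CellTiter-Glo, with a stated time of 96 h (on this read-out lower numbers stand for stronger inhibition and higher numbers for weaker inhibition), compound 1 gives 295 nM. For the measured compounds named here, a second compound, compound 2 with the structure `O=C(Nc1ccc(F)cc1)c1n[nH]cc1NC(=O)c1c(F)ccc(-c2cccc(CO)c2)c1F`, belongs to the same series, but in this assay compound 2 stands as "not determined" (no result reported), so no number is available for comparison and no step between measured compounds can be drawn.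

Compound 3, with the structure `Nc1ccc(-c2ccc(F)c(C(=O)Nc3c[nH]nc3C(=O)Nc3ccc(F)cc3)c2F)cn1`, has not yet been tested. It differs from compound 1 in one place: amino in place of carbamoyl on an aromatic carbon. The 6-carbamoylpyridin-3-yl group of compound 1 becomes a 6-aminopyridin-3-yl group in compound 3. Going by the values given here, with no measured step of this kind to lean on, the change is expected to cost a little potency, a step of a 2.0-fold higher number from compound 1 to compound 3 (0.31 log units; beyond the scatter) that lies near the edge of the scatter. For compound 3 the estimated result in this assay is 600 nM, within a range from 200 nM to 2500 nM.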

Compound 3, half-maximal inhibitory concentration: 8540 nM
Compound 3: the middle estimate sits 14-fold (1.15 log units) below what was measured, and the stated range ends below it.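

In this assay, the change at this aromatic carbon next to the ring nitrogen gives a 29-fold higher number from compound 1 to compound 3 (1.46 log units; beyond the scatter), a large step toward weaker inhibition. This shows that the position is not indifferent to what it carries: amino cannot stand in for carbamoyl here, even though each group counts one hydrogen-bond donor and one hydrogen-bond acceptor, so those counts alone do not preserve activity. Nothing available explains the drop in potency.

The compounds shown leave open which part of the carbamoyl group matters, since the change removes the carbonyl and shortens the group from three heavy atoms to one. A nitrile, a carboxylic acid or an N-methylcarbamoyl group on the same carbon would help to separate these possibilities.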